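Adding a second chloro to a purine-like core

The source may report more compounds than this note shows. Statements on the series, on what has been measured and on what is new or still open speak of the compounds shown alone.

Compound 1 `ClCc1ccccc1Cn1cnc2c(Cl)ncnc21`: 3980 nM
Compound 2 `ClCc1ccccc1Cn1cnc2ncnc(Cl)c21`: 4670 nM

Of the compounds shown here, two have been measured in a functional assay on NCI-H322M cells (Homo sapiens) for cytotoxicity, read by sulforhodamine B assay, with a stated time of 48 h; on this read-out higher numbers stand for weaker inhibition of growth and lower numbers for stronger inhibition of growth. Compound 1 gives 3980 nM in this assay, and compound 2 gives 4670 nM. The two share the same chloro-substituted fused core and the same chloromethyl-benzyl arm, differing only in how that arm is attached; their two numbers lie within the scatter of one another, so on the numbers shown compound 2 stands level with compound 1 rather than apart from it.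

Compound 3 `ClCc1ccccc1Cn1cnc2nc(Cl)nc(Cl)c21` has not yet been measured. It differs from compound 2 by chloro in place of hydrogen on an aromatic carbon. Among the measured compounds shown here, no measured pair shows what a change of this kind does to this assay, so nothing here points clearly up or down. With no guide beyond the two similar numbers of compound 1 and compound 2, the step from compound 2 to compound 3 is expected to be small, most likely not beyond the scatter, in either direction. The estimate for compound 3 is therefore 4000 nM in this assay, with a range from 1500 nM to 11000 nM, which amounts to an expected step of a 1.2-fold lower number from compound 2 to compound 3 (0.07 log units; within the scatter).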

Compound 3, concentration for 50% growth inhibition: 4260 nM
Beside the measured number, compound 3's estimate is 1.1-fold (0.03 log units) below it; the range from low to high includes it.
By their numbers in this assay, from the lowest: compounds 1, 3 and 2 (each within the scatter of the next).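

Chloro in place of hydrogen on an aromatic carbon, at the spot between two ring nitrogen atoms, is the first single change with a readable step here. Measured in this assay the step is a 1.1-fold lower number from compound 2 to compound 3 (0.04 log units; within the scatter) and so the assay does not tell the two compounds apart. This position on the six-membered aromatic ring with 2 nitrogen can therefore carry one more chlorine atom, with no hydrogen-bond donor or acceptor gained, without any step beyond the scatter; this holds for chloro at this one position and in this one assay. No measurement shown here offers an explanation for this result.

On these data alone, whether the same position stays this undemanding with a different group, such as an amine, a methoxy group or a longer chain in place of chloro, remains open. Also open, as far as these compounds go, is how the read-out would respond to a change on the chloromethyl-benzyl arm, for example a carboxylic acid or an amine in place of its chlorine.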